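Pyrazole series: chloro for trifluoromethyl on the terminal aryl urea

The source may hold more compounds than are shown below. What is called first, only, known or untested is meant among the compounds shown, and "the series" means these compounds.

Working notes on two measured compounds and one still open. Compound 1 `COc1cc(Cl)cc(-c2nn(-c3cccc(NC(=O)c4ccc(Cl)c(Cl)c4)c3)cc2-c2ccncc2)c1` carries an amide link to the terminal aryl ring; in a functional assay on CAKI-1 cells (Homo sapiens) for inhibition, read by sulforhodamine B assay, with a stated time of 48 h, tested at 10 uM (on this read-out lower numbers stand for a stronger effect and higher numbers for a weaker effect at the one concentration tested), compound 1 gives 63.6%. Compound 2 `O=C(Nc1cccc(-n2cc(-c3ccncc3)c(-c3cc(O)cc(Cl)c3)n2)c1)Nc1ccc(Cl)c(C(F)(F)F)c1`, which instead carries a urea to the same kind of terminal ring and a hydroxy group on its chlorophenyl, gives in this assay a read-out of 29.1%. Of the two numbers that of compound 2 is the lower, and the gap to compound 1 lies beyond the usual scatter. Compound 3 `O=C(Nc1cccc(-n2cc(-c3ccncc3)c(-c3cc(O)cc(Cl)c3)n2)c1)Nc1ccc(Cl)c(Cl)c1` is the next candidate and differs from compound 2 only on the terminal ring: chloro in place of trifluoromethyl on an aromatic carbon. For the measured compounds named here, no step between measured compounds covers this change, so the expectation rests on compound 2 alone. The step from compound 2 to compound 3 in this assay is expected to be small, a number 3.9 percentage points higher from compound 2 to compound 3 (within the scatter), within or at the edge of the scatter. Compound 3 is therefore estimated at 33% in this assay, with a range from 18% to 50%.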

Compound 3, a percentage reported as activity, at one concentration (the size of the read-out at that concentration, not a potency): 5.31%
Estimate against measurement, compound 3: 27.7 percentage points above; measured number outside the range, below it.
By their numbers in this assay, from the lowest: compound 3; then compound 2; then compound 1.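

On the 3,4-dichlorophenyl side of the urea, this position, ortho to a chloro group and meta to a large group, proves sensitive to the substituent: in this assay, chloro in place of trifluoromethyl gives a number 23.8 percentage points lower from compound 2 to compound 3 (beyond the scatter). For the compounds shown here, compounds 1 and 2 differ in more than one place, so this pair is the first to isolate this position, and it shows that the smaller chloro, with 1 heavy atom against 4, does not cost activity and here goes with the stronger effect. Nothing available accounts for the size of this step.

Only two substituents at this position can be compared, so no trend in size follows from them. On these data alone, whether a methyl, a nitrile or a methoxy group there would match chloro stays open, as does whether the same step would hold with the amide link of compound 1 in place of the urea.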